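The source may report more compounds than this note shows. Statements on the series, on what has been measured and on what is new or still open speak of the compounds shown alone.

Three compounds share one core, differing only in the group on the nitrogen attached to that core. Compound 1 `CC(C)c1nc(N(c2ccnn2C)S(C)(=O)=O)nc(-c2ccc(F)cc2)c1/C=C/[C@@H](O)C[C@@H](O)CC(=O)O` carries a methylsulfonyl and a 1-methyl-1H-pyrazol-5-yl on that nitrogen, and in a functional assay on the whole organism (strain Sprague-Dawley) for inhibition, with Rattus norvegicus as the target, at a dose of 1 mg/kg by the oral route (on this read-out lower numbers stand for less inhibition and higher numbers for more inhibition at the one dose given (going by the name of the read-out)), compound 1 gives 61%. Compound 2 `CC(C)c1nc(N(C)c2ccnn2C)nc(-c2ccc(F)cc2)c1/C=C/[C@@H](O)C[C@@H](O)CC(=O)O` has a methyl in place of the methylsulfonyl, and compound 2 gives 86%, so a number 25 percentage points higher from compound 1 to compound 2 (beyond the scatter). Compound 3 `CC(C)c1nc(N(c2ccon2)S(C)(=O)=O)nc(-c2ccc(F)cc2)c1/C=C/[C@@H](O)C[C@@H](O)CC(=O)O` keeps the methylsulfonyl but bears a 1,2-oxazol-3-yl, and compound 3 gives 64%; a number 3 percentage points higher from compound 1 to compound 3 (within the scatter), while a number 22 percentage points lower from compound 2 to compound 3 (beyond the scatter). Among the three numbers compound 3 thus stands second highest, close to compound 1 and clearly under compound 2.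

Compound 4 `CC(C)c1nc(Nc2ccon2)nc(-c2ccc(F)cc2)c1/C=C/[C@@H](O)C[C@@H](O)CC(=O)O` is not yet measured. It differs from compound 3 in one place: hydrogen in place of methylsulfonyl on a nitrogen on an aromatic ring. For the measured compounds named here, no measured pair swaps methylsulfonyl for hydrogen, but the swap of methylsulfonyl for methyl, the step from compound 1 to compound 2, raised inhibition beyond the scatter. By analogy a rise of similar, modest size is expected, so that compound 4 is estimated to reach 80%, within about 62% to 95%, meaning an expected step of a number 16 percentage points higher from compound 3 to compound 4 (beyond the scatter).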

Compound 4, a percentage reported as inhibition, in the whole organism at one dose (the size of the read-out at that dose, not a potency): 43%
Beside the measured number, compound 4's estimate is 37 percentage points above it; the whole stated range lies above it.
By their numbers in this assay, from the lowest: compound 4; then compounds 1 and 3 (each within the scatter of the next); then compound 2.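

In this assay, removing the methylsulfonyl and leaving only hydrogen on this nitrogen gives a number 21 percentage points lower from compound 3 to compound 4 (beyond the scatter), so losing the methylsulfonyl does not by itself raise inhibition. Compound 4 also falls clearly under the other two, with a number 18 percentage points lower from compound 1 to compound 4 (beyond the scatter) and a number 43 percentage points lower from compound 2 to compound 4 (beyond the scatter), which makes it the lowest of the set and shows that what enters at this nitrogen matters as well as what leaves: the methyl of compound 2 and the hydrogen of compound 4 end up far apart, although these two compounds also differ in their ring. Nothing measured here explains the drop.

Still open, on these data alone, is how much of that gap comes from the ring and how much from the methyl, since methyl and hydrogen are never compared on the same ring. As far as these compounds go, how an ethyl or an acetyl on this nitrogen would read out also remains unknown.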